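Triazole series: removing the tert-butyl from compound 3

This account rests on a few compounds, and the source may have more. Where it says the series, first, only, none or still open, it means among the compounds named here.

Working notes on the series. Going by the values given here, compound 3 `CC(C)(C)c1cn(C[C@H](O)[C@H]2OC(=O)C(OCc3ccccc3)=C2OCc2ccccc2)nn1` is the only member of the set that returns a number in an ADME assay on HFF cells (Homo sapiens) for cytotoxicity, read by MTT assay, with a stated time of 72 h; a higher number here means a weaker inhibitor, a lower number a stronger inhibitor; there compound 3 gives 13300 nM. Compound 1 `CCCCCc1ccc(-c2cn(C/C=C3\OC(=O)C(OCc4ccccc4)=C3OCc3ccccc3)nn2)cc1` returns only a limit of the assay, > 100000 nM. Compound 2 `COc1ccc(-c2cn(C/C=C3\OC(=O)C(OCc4ccccc4)=C3OCc3ccccc3)nn2)cc1` likewise returns only a limit, > 100000 nM. Among the compounds with values here, the one measured step, a step that the two limits leave unreadable from compound 1 to compound 2, cannot be sized, both of its ends sitting at the limit of > 100000 nM in this assay, at which 2 of the 3 values shown sit.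

Compound 4 `O=C1O[C@H]([C@@H](O)Cn2ccnn2)C(OCc2ccccc2)=C1OCc1ccccc1` is the next to be measured. The change from compound 3 is hydrogen in place of tert-butyl on an aromatic carbon. Within the data shown here, no measured step concerns the aromatic carbon of the five-membered aromatic ring with 3 nitrogen, and the single step that was measured runs between two limits, so it gives no reading of size. Nothing in the set therefore points to a shift beyond the scatter. Compound 4 is estimated at 20000 nM, within a range of 7000 nM to 60000 nM. The step of a 1.5-fold higher number from compound 3 to compound 4 (0.18 log units; within the scatter) is expected to stay inside the scatter of this assay.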

Compound 4, half-maximal inhibitory concentration: 610 nM
For compound 4 the middle estimate is 33-fold (1.52 log units) above the measured one; the whole stated range lies above it.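

Hydrogen in place of tert-butyl on the aromatic carbon of the five-membered aromatic ring with 3 nitrogen gives the first step of readable size in this assay, namely a 22-fold lower number from compound 3 to compound 4 (1.34 log units; beyond the scatter). The group on this carbon therefore has a large bearing on the read-out, and the lower number goes with the hydrogen. Going by these compounds alone, the only earlier step could not be read, as both of its ends are limits: the limit of > 100000 nM in this assay, at which 2 of the 4 values shown sit.

Nothing among the measurements shown bears on the cause of this step. Still open, going by these compounds, is how a methyl, a longer chain or an amine on this carbon would compare with tert-butyl and hydrogen, and whether a step of this size would recur on the core of compound 1.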